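This account rests on a few compounds, and the source may have more. Where it says the series, first, only, none or still open, it means among the compounds named here.

Of the compounds shown here, three have so far been measured in an ADME assay on the whole organism with Oryza sativa as the target, tested at 10 uM; a lower number here means a stronger effect, a higher number a weaker effect of the compound at the concentration tested. Compound 1 `Cc1ccc(NC(=O)N[C@H](C)c2ccccc2)cc1` gives 64%. Compound 2 `Cc1ccc(NC(=O)N[C@@H](C)c2ccccc2)cc1` gives 100%, and compound 3 `CCOC(=O)c1cccc(NC(=O)N[C@@H](C)c2ccccc2)c1` gives 96%. Among the compounds with values here, the one step between compounds that differ in a single place is a number 36 percentage points higher from compound 1 to compound 2 (beyond the scatter), and this step rests on nothing more than the fact that compounds 1 and 2 differ only in the configuration as drawn. Among the three numbers compound 2 has the top figure on its face, but the gap to compound 3 lies within the scatter, so the two cannot be told apart; only compound 1 lies clearly below compound 2.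

Compound 4 `CCOC(=O)c1ccc(NC(=O)N[C@@H](C)c2ccccc2)cc1` has not yet been measured. It differs from compound 2 by ethoxycarbonyl in place of methyl on an aromatic carbon. Within the data shown here, no measured step swaps one group for another on the ring, so none bears directly on this change; the only measured step, a number 36 percentage points higher from compound 1 to compound 2 (beyond the scatter), concerns configuration alone, and it was large. Compound 3 also carries an ethoxycarbonyl group, and its value and that of compound 2 lie within the scatter of each other. The step expected in this assay is therefore none beyond the scatter, namely a number 5 percentage points lower from compound 2 to compound 4 (within the scatter). On this basis compound 4 is estimated at 95%, within a range of 80% to 100%.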

Compound 4, a percentage reported as activity, at one concentration (the size of the read-out at that concentration, not a potency): 92%
For compound 4 the middle estimate is 3 percentage points above the measured one, within the range that was stated.
By their numbers in this assay, from the lowest: compound 1; then compounds 4, 3 and 2 (each within the scatter of the next).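

Exchanging methyl (1 heavy atom, 0 hydrogen-bond acceptors) for ethoxycarbonyl (5 heavy atoms, 2 hydrogen-bond acceptors) on an aromatic carbon, para to a large group, gives a number 8 percentage points lower from compound 2 to compound 4 (within the scatter) in this assay. Within the data shown here, this is the first measured step that changes a group on the ring rather than the configuration, and it shows that, at this place and with the configuration of compound 2, a considerably larger group does not shift the read-out by more than the scatter, so the stronger effect seen in compound 1 does not appear here. Nothing given here accounts for why this exchange leaves the number within the scatter.

On these data alone, it remains open whether a group of a different kind at this place, such as an amine or a carboxylic acid, would move the number beyond the scatter. The compounds shown also leave open whether ethoxycarbonyl would have the same small effect in the configuration drawn in compound 1, where the number starts lower and a change in either direction could be seen more easily.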